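A few compounds are considered here, and "the series" means these few. Any claim that something is new, unique, unknown or untested is made for them only; others in the source may bear on it.

Compound 1 `CCOC(=O)c1csc2nc(CN3CCN(C)CC3)c(-c3ccc(C)cc3)n12`: 58300 nM
Compound 2 `CCOC(=O)c1csc2nc(CN3CCN(C)CC3)c(-c3ccc(OC)cc3)n12`: 32800 nM

Going by the values given here, in a functional assay on MCF7 cells (Homo sapiens) for antiproliferative activity, read by MTT assay, with a stated time of 72 h (a higher number here means a weaker inhibitor, a lower number a stronger inhibitor), compound 2 gives 32800 nM, which cannot be told apart from the value of compound 1, as only two compounds have been measured and they lie within the scatter of each other. Compound 3 `CCOC(=O)c1csc2nc(CN3CCN(C)CC3)c(-c3ccc(Br)cc3)n12` replaces the group on the same aromatic carbon: bromo in place of methoxy on an aromatic carbon. That is bromo in place of methoxy. Among the compounds with values here, the one measured step at this place, a 1.8-fold lower number from compound 1 to compound 2 (0.25 log units; within the scatter), was small, so it gives no reason to expect a real shift. The expected step, a 1.1-fold higher number from compound 2 to compound 3 (0.03 log units; within the scatter), is an estimate and stays within the scatter. Compound 3 is estimated at 35000 nM, with an expected range of 13000 nM to 90000 nM.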

Compound 3, half-maximal inhibitory concentration: 68500 nM
For compound 3 the middle estimate is 2.0-fold (0.29 log units) below the measured one, within the range that was stated.
By their numbers in this assay, from the lowest: compounds 2, 1 and 3 (each within the scatter of the next, the first and the last beyond it).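

In this assay, going by these compounds alone, the change to bromo gives the first step at this aromatic carbon that lies beyond the scatter, though a modest one: a 2.1-fold higher number from compound 2 to compound 3 (0.32 log units; beyond the scatter) on swapping methoxy for bromo. Bromo and methyl, by contrast, cannot be told apart, with a 1.2-fold higher number from compound 1 to compound 3 (0.07 log units; within the scatter) in the comparison, and methoxy stays within the scatter of methyl. No measurement available here accounts for the step. Still open, as far as these compounds go, is whether an amine or a carboxylic acid on this carbon would move the number further. Also open, from the compounds shown here alone, is whether a group such as ethoxy would track methoxy.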